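The source may report more compounds than this note shows. Statements on the series, on what has been measured and on what is new or still open speak of the compounds shown alone.

Three relatives frame the question: compound 1 (`O=C(CCCCC(S)CCS)NO`), compound 2 (`O=C(CCCCC1CCSS1)Nc1ccc(Cl)cn1`) and compound 3 (`O=C(CCCCC(S)CCS)Nc1ccccn1`). In a functional assay on KB cells (Homo sapiens) for inhibition, read by MTT assay, with a stated time of 24 h, tested at 1 ug/mL (on this read-out lower numbers stand for less inhibition of growth and higher numbers for more inhibition of growth at the one concentration tested), compound 1 gives 10.6% and compound 2 gives 0.76% as its reading, two values within the usual scatter of each other. Compound 3 has no single number and is reported as "not active" (no number reported) with no figure attached. Compound 4 (`O=C(CCCCC(S)CCS)Nc1ccc(Cl)cn1`) is still unmeasured. Among the measured compounds shown here, the one structural change is chloro in place of hydrogen on an aromatic carbon and amounts to chloro in place of hydrogen on an aromatic carbon. For the measured compounds named here, no measured step shows what this change does, so no shift beyond the scatter is expected in this assay in either direction. Compound 2, which also carries chloro, gives just 0.76% as its reading. Compound 4 is estimated at 4% with an expected range from 0% to 15% as its span.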

Compound 4, percent growth inhibition at one concentration: "not active" (no number reported)
Nothing numeric was reported for compound 4, so the estimate cannot be set against anything.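

Compound 3 and compound 4 are both reported only as "not active", with no number, so no step can be read between them. From the compounds shown here alone, the effect of chloro in place of hydrogen on growth inhibition therefore stays open, and no supporting evidence bears on this result.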